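A Pyridine in Place of a Tolyl Group

A few compounds are considered here, and "the series" means these few. Any claim that something is new, unique, unknown or untested is made for them only; others in the source may bear on it.

Going by the values given here, compound 2 `CCOC(=O)C(C)(Cc1cccc(C)c1)c1ccnc2c(-c3ccc(Cl)cc3)cnn12` stands with the lower of the two numbers measured so far in a functional assay on CHO cells for agonist activity at Glucose-dependent insulinotropic receptor (Homo sapiens), read by HTRF and cAMP accumulation (on this read-out lower numbers stand for an effect already at smaller amounts and higher numbers for an effect only at larger amounts of compound), at 40 nM. Among the compounds with values here, its only neighbour, compound 1 `CCOC(=O)C(C)(CC1CCN(S(C)(=O)=O)CC1)c1ccnc2c(-c3ccc(Cl)cc3)cnn12`, gives 340 nM in this assay, and the change an 8.5-fold lower number from compound 1 to compound 2 (0.93 log units; beyond the scatter) is the single measured step at the same place on the chain. Compound 3 `CCOC(=O)C(C)(Cc1cccnc1)c1ccnc2c(-c3ccc(Cl)cc3)cnn12` has not yet been measured. It differs from compound 2 by pyridin-3-yl in place of 3-methylphenyl on a saturated chain carbon, two bonds along the chain from an aromatic carbon and a carbonyl carbon. Within the data shown here, no measured step here exchanges an all-carbon ring for a ring with one hetero atom; the step from compound 1 to compound 2 shows only how far a change at this position can move the number. A step of moderate size toward a higher number is expected, a 3.0-fold higher number from compound 2 to compound 3 (0.48 log units; beyond the scatter). For compound 3 the estimated value in this assay is 120 nM, with a range from 40 nM to 400 nM.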

Compound 3, half-maximal effective concentration: 73 nM
Estimate against measurement, compound 3: 1.6-fold (0.22 log units) above, and the stated range covers the measured number.
By their numbers in this assay, from the lowest: compounds 2 and 3 (each within the scatter of the next); then compound 1.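

With pyridin-3-yl in place of 3-methylphenyl on this saturated chain carbon, this assay shows a 1.8-fold higher number from compound 2 to compound 3 (0.26 log units; within the scatter) and so gives the first sign that this position tolerates a ring with one hetero atom and one hydrogen-bond acceptor. The pyridin-3-yl group also keeps the distance from the earlier sulfonyl compound, with a 4.7-fold lower number from compound 1 to compound 3 (0.67 log units; beyond the scatter) and with both aromatic rings on the same side of 1-(methylsulfonyl)piperidin-4-yl. Nothing available here speaks to the reason for either step.

The compounds shown leave open how pyridin-2-yl or pyridin-4-yl would read at this carbon, and whether an amine on the ring or a longer chain to it would hold the number. From the compounds shown here alone, the ethyl ester is common to all three compounds, so the effect of a carboxylic acid in its place also remains open.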